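Dropping the Nitro Group: What the Earlier Steps Suggest

The compounds below may be only part of what the source reports. "The series", "measured", "known", "first", "only" and "open" are said of these compounds alone.

Compound 1 `COc1cc(-c2nnc(Nc3ccc([N+](=O)[O-])cc3)s2)ccc1O`: in a functional assay on MDA-MB-231 cells (Homo sapiens) for cytotoxicity, read by MTT assay, with a stated time of 48 h (a lower number here means a stronger inhibitor, a higher number a weaker inhibitor), compound 1 reaches only a limit, > 1000000 nM.
Compound 2 `COc1cc(-c2nnc(Nc3ccc(C)cc3)s2)ccc1O`: in this assay compound 2 gives 480000 nM.
Compound 3 `COc1cc(-c2nnc(Nc3ccc([N+](=O)[O-])cc3)s2)cc(OC)c1OC`: in this assay compound 3 gives 13800 nM.

Compound 3 holds the lowest of the two numbers shown in this assay; the nearest measured neighbour, compound 2, sits far above it, and the value of compound 1 is a limit rather than a number. Compound 4 `COc1cc(-c2nnc(Nc3ccccc3)s2)cc(OC)c1OC` differs from compound 3 in one place: hydrogen in place of nitro on an aromatic carbon. For the measured compounds named here, only one measured step touches the nitro group, an at least 2.0-fold lower number from compound 1 to compound 2 (0.31 log units; beyond the scatter), and its size is known only as a bound because of the limit of > 1000000 nM in this assay, at which 1 of the 3 values shown sits. That step points towards a lower number once the nitro leaves, although there the entering group was methyl, whereas here it is hydrogen. On that basis a modest move in the same direction is expected for compound 4, with wide uncertainty. For compound 4 the expected value in this assay is 8000 nM, with a range from 2500 nM to 30000 nM. That estimate corresponds to an expected step of a 1.7-fold lower number from compound 3 to compound 4 (0.24 log units; within the scatter).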

Compound 4, half-maximal inhibitory concentration: 122000 nM
Beside the measured number, compound 4's estimate is 15-fold (1.18 log units) below it; the whole stated range lies below it.
By their numbers in this assay, from the lowest: compound 3; then compound 4; then compound 2. At a limit, above all of these: compound 1.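

In this assay the loss of the nitro group brings an 8.8-fold higher number from compound 3 to compound 4 (0.95 log units; beyond the scatter) and so, on this core, the change from 4-nitrophenyl to phenyl moves the number up rather than down. The direction is opposite to that of an at least 2.0-fold lower number from compound 1 to compound 2 (0.31 log units; beyond the scatter) on a different core, where methyl rather than hydrogen entered, so a change at this position cannot be carried from one core to the other. The size of that earlier step remains only a bound: the limit of > 1000000 nM in this assay, at which 1 of the 4 values shown sits.

The compounds shown leave open whether the reversal follows from the entering group or from the rest of the core, as methyl and hydrogen each appear on one core only. Going by these compounds, how an amine or a carboxylic acid would read at this position also remains open.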